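Aryl variation on the amidine nitrogen of the naphthoquinone series

A few compounds are considered here, and "the series" means these few. Any claim that something is new, unique, unknown or untested is made for them only; others in the source may bear on it.

Measured compounds:
- compound 1 `Cc1ccc(S(=O)(=O)/N=C(/CCNC2=CC(=O)c3ccccc3C2=O)Nc2ccc(F)cc2)cc1`: 12200 nM
- compound 2 `Cc1ccc(S(=O)(=O)/N=C(/CCNC2=CC(=O)c3ccccc3C2=O)Nc2ccccc2[N+](=O)[O-])cc1`: 7590 nM
- compound 3 `COc1cc(N/C(CCNC2=CC(=O)c3ccccc3C2=O)=N\S(=O)(=O)c2ccc(C)cc2)cc(OC)c1OC`: 9330 nM

In a functional assay on DU-145 cells (Homo sapiens) for cytotoxicity, read by MTT assay, with a stated time of 48 h (a lower number here means a stronger inhibitor, a higher number a weaker inhibitor), compound 2 gives the smallest number of the three, yet its steps to both neighbours stay inside the scatter: a 1.6-fold lower number from compound 1 to compound 2 (0.21 log units; within the scatter) and a 1.2-fold higher number from compound 2 to compound 3 (0.09 log units; within the scatter). Likewise a 1.3-fold lower number from compound 1 to compound 3 (0.12 log units; within the scatter). Compound 4 `Cc1ccc(S(=O)(=O)/N=C(/CCNC2=CC(=O)c3ccccc3C2=O)Nc2cc(F)c(F)c(F)c2)cc1` differs from compound 2 only on the amine nitrogen: 3,4,5-trifluorophenyl in place of 2-nitrophenyl on an amine nitrogen. Every aryl exchange measured so far on this nitrogen left this assay unchanged beyond the scatter, so no step beyond the scatter is expected for the trifluorophenyl either, and compound 4 is expected near a 1.3-fold higher number from compound 2 to compound 4 (0.10 log units; within the scatter). Compound 4 is estimated at 9500 nM, ranging from 4000 nM to 22000 nM.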

Compound 4, half-maximal inhibitory concentration: 12600 nM
Beside the measured number, compound 4's estimate is 1.3-fold (0.12 log units) below it, within the range that was stated.
By their numbers in this assay, from the lowest: compounds 2, 3, 1 and 4 (each within the scatter of the next).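

In this assay, 3,4,5-trifluorophenyl on the amine nitrogen also stays within the scatter of all three earlier aryl groups (a 1.7-fold higher number from compound 2 to compound 4 (0.22 log units; within the scatter); a 1.4-fold higher number from compound 3 to compound 4 (0.13 log units; within the scatter); a 1.0-fold higher number from compound 1 to compound 4 (0.01 log units; within the scatter)). The flat picture at this position now also covers the exchange of 2-nitrophenyl, with 2 hydrogen-bond acceptors, for an aryl with 0 hydrogen-bond acceptors. No available evidence accounts for this flatness.

Open, on these data alone, is whether a non-aromatic group such as cyclohexyl, or an aryl carrying a carboxylic acid, would step beyond the scatter on this nitrogen. Changes elsewhere on the shared core also remain open.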